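Amide variation on the diketopiperazine oxytocin series

This account rests on a few compounds, and the source may have more. Where it says the series, first, only, none or still open, it means among the compounds named here.

Compound 2 `CC[C@H](C)[C@@H]1C(=O)N[C@H](C2Cc3ccccc3C2)C(=O)N1[C@@H](C(=O)N1CCOCC1)c1cc(C)cnc1C` stands second highest of the three numbers in an assay on isolated protein for displacement of a labelled ligand from Oxytocin receptor (Homo sapiens) (a lower number here means a stronger inhibitor, a higher number a weaker inhibitor), with compound 2 giving 0.794 nM. Among the measured compounds shown here, compound 1 `CC[C@H](C)[C@@H]1C(=O)N[C@H](C2Cc3ccccc3C2)C(=O)N1[C@@H](C(=O)N1CCOCC1)c1cnc(C)cc1C` gives 0.0501 nM, and the step of a 16-fold higher number from compound 1 to compound 2 (1.20 log units; beyond the scatter) is the only measured step in the set. Compound 3 `Cc1ccc([C@H](C(=O)N2CCOCC2)N2C(=O)[C@@H](C3Cc4ccccc4C3)NC(=O)[C@H]2CC2CC2)cn1` gives 5.01 nM, the highest number of the three.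

Compound 4 `CC[C@H](C)[C@@H]1C(=O)N[C@H](C2Cc3ccccc3C2)C(=O)N1[C@@H](C(=O)NC)c1cc(C)cnc1C` differs from compound 2 by methylamino in place of morpholin-4-yl on a carbonyl carbon. For the measured compounds named here, no measured step in this assay touches the amide carbonyl: the one step on hand, a 16-fold higher number from compound 1 to compound 2 (1.20 log units; beyond the scatter), concerns the aryl group, and the gap between compound 2 and compound 3 involves two simultaneous changes. Going by the values given here, there is therefore no direct precedent for the size or direction of the amide exchange. The expectation is a step of a 1.3-fold higher number from compound 2 to compound 4 (0.10 log units; within the scatter), meaning no change beyond the scatter, with a wide range to reflect the lack of precedent. Compound 4 is expected to give 1 nM in this assay, estimated between 0.25 nM and 4 nM.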

Compound 4, inhibition constant: 1.26 nM
Compound 4: the middle estimate sits 1.3-fold (0.10 log units) below what was measured; measured number inside the range.
By their numbers in this assay, from the lowest: compound 1; then compounds 2 and 4 (each within the scatter of the next); then compound 3.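

In this assay, methylamino in place of morpholin-4-yl on the carbonyl carbon gives a 1.6-fold higher number from compound 2 to compound 4 (0.20 log units; within the scatter) and so stays within the scatter; the two compounds cannot be told apart. Among the compounds shown here, this is the first measured step at the amide, and it shows that, with the 2,5-dimethylpyridin-3-yl group in place, swapping the morpholine ring for a small amide carrying a hydrogen-bond donor leaves the number within the scatter, unlike the aryl step of a 16-fold higher number from compound 1 to compound 2 (1.20 log units; beyond the scatter) in the same series. No supporting data bear on why the amide exchange leaves the number within the scatter.

As far as these compounds go, whether the same exchange holds with the 4,6-dimethylpyridin-3-yl group of compound 1 remains open. Also open, from the compounds shown here alone, is how a dimethylamino group, a piperazin-1-yl ring or a longer chain on the amide nitrogen would read at this carbonyl carbon.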